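The source may hold more compounds than are shown below. What is called first, only, known or untested is meant among the compounds shown, and "the series" means these compounds.

Three compounds were measured in a functional assay on KBVIN cells (Homo sapiens) for antiproliferative activity, read by sulforhodamine B assay, with a stated time of 3 days; on this read-out lower numbers stand for stronger inhibition of growth and higher numbers for weaker inhibition of growth:

Compound 1, `O=C(Nc1ccccn1)c1cccc(Nc2ncc(F)c(Nc3ccc(F)cc3)n2)c1`: 13700 nM
Compound 2, `CN1CCC(C(=O)Nc2cccc(Nc3ncc(F)c(Nc4ccc(F)cc4)n3)c2)CC1`: 11900 nM
Compound 3, `CN(C)c1ccc(C(=O)Nc2cccc(Nc3ncc(F)c(Nc4ccc(F)cc4)n3)c2)cc1`: > 10000 nM

All three share one core and differ only in the group on one aromatic carbon. Compound 1 and compound 2 sit inside the usual scatter of each other: a 1.2-fold lower number from compound 1 to compound 2 (0.06 log units; within the scatter). Compound 3 is reported only as a limit, > 10000 nM. Hence a step that the limit leaves unreadable from compound 2 to compound 3, because of the limit of > 10000 nM in this assay, at which 1 of the 3 values shown sits.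

Compound 4, `COCC(=O)Nc1cccc(Nc2ncc(F)c(Nc3ccc(F)cc3)n2)c1`, is not yet measured. It differs from compound 1 in this way: ((methoxymethyl)carbonyl)amino in place of (pyridin-2-yl)carbamoyl on an aromatic carbon. Both measured steps change the same position, and neither shows a readable move, so no step beyond the scatter is expected in this assay. Compound 4 is therefore expected to give 12000 nM, in a range from 4000 nM to 40000 nM. That expectation means a step of a 1.1-fold lower number from compound 1 to compound 4 (0.06 log units; within the scatter).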

Compound 4, concentration for 50% growth inhibition: 3940 nM
The estimate for compound 4 lay 3.0-fold (0.48 log units) above the measured number, and the stated range ends above it.
By their numbers in this assay, from the lowest: compound 4; then compounds 2 and 1 (each within the scatter of the next).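

In this assay, this position does respond to change: the ((methoxymethyl)carbonyl)amino group, which has no ring, gives a 3.5-fold lower number from compound 1 to compound 4 (0.54 log units; beyond the scatter) and a 3.0-fold lower number from compound 2 to compound 4 (0.48 log units; beyond the scatter). Compound 3 stands only as a limit, so its comparison is a bound, an at least 2.5-fold lower number from compound 3 to compound 4 (0.40 log units; beyond the scatter). That bound rests on a single limit value: the limit of > 10000 nM in this assay, at which 1 of the 4 values shown sits.

The compounds shown leave open whether this step goes with the missing ring or with the methoxy group itself. A longer chain such as methoxyethyl, or an amine such as dimethylamino in place of methoxy, would bear on that question.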